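Swapping the phenyl for a hydroxyethyl tail

This account rests on a few compounds, and the source may have more. Where it says the series, first, only, none or still open, it means among the compounds named here.

Measured compounds:
- Compound 1 `COc1nc2ccc(Br)cc2cc1C(c1ccccc1)n1cc(-c2ccccc2)nn1`: 30.1%
- Compound 2 `CCCCc1cn(C(c2ccccc2)c2cc3cc(Br)ccc3nc2OC)nn1`: 5.46%
- Compound 3 `CCCc1cn(C(c2ccccc2)c2cc3cc(Br)ccc3nc2OC)nn1`: 11.3%

All three share one core and differ only in the group on the five-membered ring. In an ADME assay on PANC-1 cells (Homo sapiens) for cytotoxicity, read by sulforhodamine B assay, with a stated time of 48 h, tested at 10 uM (on this read-out higher numbers stand for more inhibition at the one concentration tested (going by the name of the read-out) and lower numbers for less inhibition), compound 1 gives the highest of the three numbers; its steps to compound 3 and to compound 2 both lie beyond the scatter. The step of a number 24.6 percentage points lower from compound 1 to compound 2 (beyond the scatter) and the step of a number 18.8 percentage points lower from compound 1 to compound 3 (beyond the scatter) show that trading the phenyl for a plain alkyl chain cost a modest amount of inhibition in each case. Between the two chains themselves the step of a number 5.8 percentage points higher from compound 2 to compound 3 (within the scatter) is within the scatter, so nothing can be said about their order.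

Compound 4 `COc1nc2ccc(Br)cc2cc1C(c1ccccc1)n1cc(CCO)nn1` makes a change of the same kind: 2-hydroxyethyl in place of phenyl on an aromatic carbon. Like the two measured steps, it removes the phenyl and puts a short chain in its place, so a modest loss in this assay is expected, of about a number 19.1 percentage points lower from compound 1 to compound 4 (beyond the scatter). A 2-hydroxyethyl group has not been tried here, so the range is kept wide. Compound 4 is therefore estimated at 11%, within 0% to 25%.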

Compound 4, a percentage reported as inhibition, at one concentration (the size of the read-out at that concentration, not a potency): 19.8%
Estimate against measurement, compound 4: 8.8 percentage points below; the measured number falls inside the stated range.
By their numbers in this assay, from the lowest: compounds 2, 3 and 4 (each within the scatter of the next, the first and the last beyond it); then compound 1.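

In this assay, 2-hydroxyethyl is the first replacement for the phenyl at this position to bring a hydrogen-bond donor and acceptor, yet inhibition still falls (a number 10.3 percentage points lower from compound 1 to compound 4 (beyond the scatter)), so compound 1 stays above every replacement shown here, each step beyond the scatter. Against the plain alkyl chains the result splits: compound 4 cannot be told apart from the propyl chain of compound 3 (a number 8.5 percentage points higher from compound 3 to compound 4 (within the scatter)), but it does separate from the butyl chain of compound 2 (a number 14.3 percentage points higher from compound 2 to compound 4 (beyond the scatter)), so the hydroxy-bearing chain shows a real difference in only one of the two comparisons. No measurement available here accounts for either the loss against the phenyl or the difference from the butyl chain.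

As far as these compounds go, with so few compounds, it stays open whether the hydroxy group or the length of the chain decides the difference from compound 2, which a 3-hydroxypropyl chain or a 4-hydroxybutyl chain could help to separate. From the compounds shown here alone, it is equally open how an amine or a carboxylic acid at the end of the chain would read, and whether any group at this position can match the phenyl.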